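The source may hold more compounds than are shown below. What is called first, only, known or untested is meant among the compounds shown, and "the series" means these compounds.

Measured compounds:
- compound 1, `CCOC(=O)C[C@H]1[C@@H](O[Si](C)(C)C(C)(C)C)[C@H](n2cnc3c(NC(=O)Nc4ccccc4)ncnc32)O[C@@H]1COC(=O)NC`, with 10.3 nM
- compound 2, `CNC(=O)NC[C@H]1O[C@@H](n2cnc3c(NC(=O)Nc4ccccc4)ncnc32)[C@H](O[Si](C)(C)C(C)(C)C)[C@@H]1CC(=O)N(C)OC`, with 9.02 nM

Both measured compounds were tested in a functional assay on OVCAR-8 cells (Homo sapiens) for antiproliferative activity; a lower number here means a stronger inhibitor of growth, a higher number a weaker inhibitor of growth. In this assay compound 1 gives 10.3 nM, and compound 2 gives 9.02 nM. Compound 2 carries the lowest of the two numbers, but its nearest neighbour, compound 1, sits within the scatter of it, so the two values cannot be told apart; neither compound can be called the stronger inhibitor of growth on these figures.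

The step considered here leads from compound 2 to compound 3, `CCOC(=O)C[C@H]1[C@@H](O[Si](C)(C)C(C)(C)C)[C@H](n2cnc3c(NC(=O)Nc4ccccc4)ncnc32)O[C@@H]1CNC(=O)NC`, which has not yet been tested in this assay. The two compounds differ in one place: ethoxy in place of methoxy(methyl)amino on a carbonyl carbon. Compound 3 thus combines the ethoxycarbonyl group already present in compound 1 with the rest of compound 2.

For the measured compounds named here, no step between measured compounds that differ in one place is available, so the size of the change in this assay is not known from direct comparison. Since compound 1 carries the same ethoxycarbonyl group and gives 10.3 nM, close to compound 2, the step is expected to be small and to stay within the scatter, a 1.1-fold higher number from compound 2 to compound 3 (0.04 log units; within the scatter). For compound 3 the estimated value in this assay is 10 nM, expected to lie between 4 nM and 25 nM.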

Compound 3, concentration for 50% growth inhibition: 4.92 nM
For compound 3 the middle estimate is 2.0-fold (0.31 log units) above the measured one, within the range that was stated.
By their numbers in this assay, from the lowest: compounds 3, 2 and 1 (each within the scatter of the next, the first and the last beyond it).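

In this assay, the exchange of methoxy(methyl)amino for ethoxy on a carbonyl carbon whose other neighbour is a saturated chain carbon gives a 1.8-fold lower number from compound 2 to compound 3 (0.26 log units; within the scatter) and so cannot be told apart from no change, which means that either group is compatible with a number of this order at this position. For the compounds shown here, the other pair adds what the earlier compounds could not show, since (methylcarbamoyl)amino in place of (methylcarbamoyl)oxy on a saturated chain carbon bound to a saturated ring carbon gives a 2.1-fold lower number from compound 1 to compound 3 (0.32 log units; beyond the scatter) and is the only step here beyond the scatter, though a modest one resting on a single pair. Nothing among the data shown accounts for either step.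

The compounds shown leave open whether a carboxylic acid, a primary amide or a longer alkoxy chain on that carbonyl carbon would stay in the same range. They also leave open whether the gain from the (methylcarbamoyl)amino group would recur with methoxy(methyl)amino on the carbonyl carbon, and whether a plain amine on the saturated chain carbon would serve as well.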